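The compounds below may be only part of what the source reports. "The series", "measured", "known", "first", "only" and "open" are said of these compounds alone.

Compound 1 `COc1ccc(C2=NN(C3=NC(=O)/C(=C4\C(=O)Nc5ccccc54)S3)C(c3ccc(OC)cc3)C2)cc1` gives 100000 nM in a functional assay on cells (Cancer cell lines, Homo sapiens) for cytotoxicity, read by sulforhodamine B assay, with a stated time of 48 h; on this read-out higher numbers stand for weaker inhibition of growth and lower numbers for stronger inhibition of growth. Compound 3 `COc1ccc(C2=NN(C3=NC(=O)/C(=C4\C(=O)Nc5ccccc54)S3)C(c3ccc(Cl)cc3)C2)cc1` differs from compound 1 by chloro in place of methoxy on an aromatic carbon, and in this assay compound 3 gives 100000 nM; the step of no change at the digits printed from compound 1 to compound 3 (within the scatter) shows that this exchange on the shared core left the read-out where it was. Compound 2 `COc1ccc(C2CC(c3ccc4ccccc4c3)=NN2C2=NC(=O)/C(=C3\C(=O)Nc4ccccc43)S2)cc1` carries a different change from compound 1, (naphthalen-2-yl in place of 4-methoxyphenyl on a carbon with a double bond to nitrogen), and compound 2 gives 2470 nM; here the step of a 40-fold lower number from compound 1 to compound 2 (1.61 log units; beyond the scatter) is large. Compound 4 `O=C1N=C(N2N=C(c3ccc4ccccc4c3)CC2c2ccc(Cl)cc2)S/C1=C1/C(=O)Nc2ccccc21` has not yet been measured. It differs from compound 3 by naphthalen-2-yl in place of 4-methoxyphenyl on a carbon with a double bond to nitrogen. This is the same kind of change as from compound 1 to compound 2, though not the same: in compound 4 the carbon two ring bonds away bears a 4-chlorophenyl group, where in compound 2 it bears a 4-methoxyphenyl group. Since no change at the digits printed from compound 1 to compound 3 (within the scatter) showed no effect of that chloro for methoxy swap, the expected step of a 33-fold lower number from compound 3 to compound 4 (1.52 log units; beyond the scatter) is estimated to resemble a 40-fold lower number from compound 1 to compound 2 (1.61 log units; beyond the scatter). Compound 4 is therefore expected at about 3000 nM, estimated to fall between 800 nM and 15000 nM.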

Compound 4, concentration for total growth inhibition: 50700 nM
Beside the measured number, compound 4's estimate is 17-fold (1.23 log units) below it; measured number above the stated range.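

In this assay, the exchange of 4-methoxyphenyl for naphthalen-2-yl gives only a 2.0-fold lower number from compound 3 to compound 4 (0.29 log units; within the scatter), so a large step on the core of compound 1 did not carry over to the core bearing 4-chlorophenyl: the same change on two cores in this assay, a 40-fold lower number (1.61 log units; beyond the scatter) from compound 1 to compound 2 and a 2.0-fold lower number (0.29 log units; within the scatter) from compound 3 to compound 4, 21-fold (1.31 log units) apart, beyond the scatter of two such steps

The chloro for methoxy exchange also depends on its surroundings, since it gives a 21-fold higher number from compound 2 to compound 4 (1.31 log units; beyond the scatter) when naphthalen-2-yl is present, although it left the number unchanged on the core of compound 1: the same change on two cores in this assay, no change at the digits printed (within the scatter) from compound 1 to compound 3 and a 21-fold higher number (1.31 log units; beyond the scatter) from compound 2 to compound 4, 21-fold (1.31 log units) apart, beyond the scatter of two such steps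

These four compounds show that, here, the effect of either change depends on the other, so neither step can simply be transferred, but they do not show why this happens or whether it would hold on any other core.

As far as these compounds go, it remains open whether the low number of compound 2, 2470 nM, depends on methoxy in particular. A hydroxy group or an amine in that place on the aromatic carbon, alongside naphthalen-2-yl, would test this.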